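This account rests on a few compounds, and the source may have more. Where it says the series, first, only, none or still open, it means among the compounds named here.

Measured so far in a functional assay (muscle tissue) with Cavia porcellus as the target; a lower number here means that less compound is needed, a higher number that more compound is needed for the effect:
Compound 1 `COC(=O)C1=C(C)N=C(C)/C(=C(\O)OC)C1c1ccccc1N`: 39800 nM
Compound 2 `COC(=O)C1=C(C)N=C(C)/C(=C(\O)OC)C1c1ccccc1OC`: 57.5 nM

Of these two, compound 2 has the lower number, and it is the better reference point for what comes next. The next compound, compound 3 `COC(=O)C1=C(C)N=C(C)/C(=C(\O)OC)C1c1ccccc1C(F)(F)F`, keeps the shared core and changes one group: trifluoromethyl in place of methoxy on an aromatic carbon. Within the data shown here, only one measured step bears on this change: a 690-fold lower number from compound 1 to compound 2 (2.84 log units; beyond the scatter). That step, with methoxy in place of amino on an aromatic carbon, is large, so in this pair the number responds strongly to the group exchanged. Among the measured compounds shown here, still, it is a single step, and no measured compound carries trifluoromethyl, so the data give no direct guide to the size or the direction of the new change. A step as large as that one is not expected here, since compound 3 also lacks the amino group of compound 1, which gives 39800 nM. A moderate move to a lower number in this assay is the tentative expectation, and the expected size is a 5.8-fold lower number from compound 2 to compound 3 (0.76 log units; beyond the scatter). Compound 3 is estimated at 10 nM, with an expected range from 2 nM to 50 nM.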

Compound 3, half-maximal effective concentration: 1.51 nM
Beside the measured number, compound 3's estimate is 6.6-fold (0.82 log units) above it, and the stated range ends above it.
By their numbers in this assay, from the lowest: compound 3; then compound 2; then compound 1.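

In this assay, the exchange of methoxy for trifluoromethyl on this aromatic carbon, ortho to a large group, gives a 38-fold lower number from compound 2 to compound 3 (1.58 log units; beyond the scatter), so the position still responds strongly once the amino group is gone, and methoxy did not mark the end of the range. Measured against the amino group, the same trifluoromethyl gives a 26000-fold lower number from compound 1 to compound 3 (4.42 log units; beyond the scatter), and the three compounds now span a wide range through changes at this single place, in the order trifluoromethyl, methoxy, amino from the lowest number. Nothing measured here explains why trifluoromethyl gives the lowest number of the three.

Among these compounds, with only three groups compared, it remains open whether a nitro group, a chlorine atom or a nitrile at the same place would give a number lower still or fall between these values. Going by these compounds, it is also open whether trifluoromethyl would keep its lead when placed elsewhere on the aromatic ring, or when the methyl esters of the shared core give way to longer chains.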